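Sulfamoyl carbamates: chain length on the sulfamoyl nitrogen

A few compounds are considered here, and "the series" means these few. Any claim that something is new, unique, unknown or untested is made for them only; others in the source may bear on it.

Two carbamates have been measured in an assay on liver for inhibition of sterol O-acyltransferase 1 (Rattus norvegicus), using microsomes; a lower number here means a stronger inhibitor, a higher number a weaker inhibitor. Compound 1 `CC(C)c1cccc(C(C)C)c1OC(=O)NS(=O)(=O)N(C(C)C)C1CCCCC1` gives 5100 nM there, and compound 2 `Cc1cc(C(C)(C)C)c(OC(=O)NS(=O)(=O)N(C(C)C)C(C)C)c(C(C)(C)C)c1` gives 3200 nM; the two numbers sit within the scatter of each other, so neither is set apart. Compound 3 `CCCCCCCCN(C)S(=O)(=O)NC(=O)Oc1c(C(C)(C)C)cc(C)cc1C(C)(C)C` is compound 2 with methyl(octyl)amino in place of diisopropylamino on a sulfonyl sulfur. Among the measured compounds shown here, no measured pair shows the effect of such a change, so the step from compound 2 to compound 3 can only be guessed; a modest gain is expected, a 1.6-fold lower number from compound 2 to compound 3 (0.20 log units; within the scatter), though nothing beyond the scatter would also fit. Compound 3 is expected to give about 2000 nM in this assay, within 600 nM to 6500 nM.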

Compound 3, half-maximal inhibitory concentration: 18000 nM
Estimate against measurement, compound 3: 9.0-fold (0.95 log units) below; measured number outside the range, above it.
By their numbers in this assay, from the lowest: compounds 2 and 1 (each within the scatter of the next); then compound 3.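

Among the compounds shown here, on the sulfonyl sulfur, the amino group does change the result in this assay: methyl(octyl)amino in place of diisopropylamino gives a 5.6-fold higher number from compound 2 to compound 3 (0.75 log units; beyond the scatter), the first step beyond the scatter. On the core of compound 2, this change weakens inhibition rather than improving it. No measurement here bears on why the number rises.

On these data alone, it remains open whether the loss follows the octyl chain or the departure of the two isopropyl groups. Methyl(butyl)amino or dimethylamino at this place would help separate those two readings.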